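Compound 3: a plain phenyl amide derived from compound 1

The compounds below may be only part of what the source reports. "The series", "measured", "known", "first", "only" and "open" are said of these compounds alone.

Compound 1 `COc1c(Br)cccc1C(=O)Nc1ccc(Sc2nc3ccccc3s2)c(Cl)c1` is one of two compounds examined in an ADME assay on HEK293 cells (Homo sapiens) for cytotoxicity, read by reporter gene assay and resazurin assay, with a stated time of 48 h; a higher number here means that more compound is tolerated, a lower number that less compound is tolerated. In this assay compound 1 returns only a limit, > 100000 nM. Compound 2 `COc1ccc(Br)cc1C(=O)Nc1ccccc1` likewise returns a limit in this assay, > 100000 nM. Both results sit at the same boundary: the limit of > 100000 nM in this assay, at which 2 of the 2 values shown sit. Compound 3 `O=C(Nc1ccc(Sc2nc3ccccc3s2)c(Cl)c1)c1ccccc1` differs from compound 1 by a group of 6 heavy atoms (6 carbon; one six-membered aromatic ring of carbon only) in place of a group of 9 heavy atoms (7 carbon, 1 oxygen, 1 bromine; one six-membered aromatic ring of carbon only), on a carbonyl carbon. For the measured compounds named here, no measured step between compounds is available, so for compound 3 no shift beyond the scatter in this assay is expected. Compound 3 is therefore estimated at 150000 nM, within 50000 nM to 500000 nM. The expected step is a step that the limit leaves unreadable from compound 1 to compound 3.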

Compound 3, half-maximal cytotoxic concentration: 90000 nM
Compound 3: middle estimate off by 1.7-fold (0.22 log units), on the high side; the measured number falls inside the stated range.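

For the compounds shown here, with phenyl on the carbonyl carbon, compound 3 gives the first number in this assay that is not a limit. Phenyl in place of the group of 9 heavy atoms gives an at least 1.1-fold lower number from compound 1 to compound 3 (0.04 log units; that floor lies within the scatter), so this change cannot be told apart from no change, though the true step may be larger. The value for compound 1 remains a limit: the limit of > 100000 nM in this assay, at which 2 of the 3 values shown sit.

From the compounds shown here alone, it remains open whether the bromine or the oxygen of the departing group matters on its own. Also open, going by these compounds, is how an amine or a carboxylic acid on that ring would read in this assay.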